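Triazene ester series: methoxy in place of methyl

The source may report more compounds than this note shows. Statements on the series, on what has been measured and on what is new or still open speak of the compounds shown alone.

Measured so far:
compound 1 `CCOC(=O)c1sc2ccccc2c1/N=N/Nc1ccc(F)c(Cl)c1`, in a functional assay on HeLa cells (Homo sapiens) for cytotoxicity, read by MTT assay, with a stated time of 24 h (on this read-out higher numbers stand for weaker inhibition of growth and lower numbers for stronger inhibition of growth), compound 1 gives 31400 nM
compound 2 `CCOC(=O)c1sc2ccccc2c1/N=N/Nc1ccc(C)cc1`, in this assay compound 2 gives 42100 nM

Compound 2 holds the higher of the two numbers in this assay; compound 1 is the nearest, and the step of a 1.3-fold higher number from compound 1 to compound 2 (0.13 log units; within the scatter) lies within the scatter, so no order between the two can be read from it. Compound 3 `CCOC(=O)c1sc2ccccc2c1/N=N/Nc1ccc(OC)cc1` is the unmeasured member of the series. Against compound 2 it carries methoxy in place of methyl on an aromatic carbon. Within the data shown here, the only measured step that touches the aryl group on the amine nitrogen is a 1.3-fold higher number from compound 1 to compound 2 (0.13 log units; within the scatter), and it stayed within the scatter; no measured pair trades methyl for methoxy. The expectation is therefore no movement beyond the scatter, with the direction undecided. Compound 3 is expected to give about 40000 nM in this assay, with a range from 15000 nM to 110000 nM. The estimated step is a 1.1-fold lower number from compound 2 to compound 3 (0.02 log units; within the scatter).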

Compound 3, concentration for 50% growth inhibition: 49100 nM
Estimate against measurement, compound 3: 1.2-fold (0.09 log units) below; measured number inside the range.
By their numbers in this assay, from the lowest: compounds 1, 2 and 3 (each within the scatter of the next).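

In this assay, methoxy in place of methyl on an aromatic carbon, para to a large group, gives a 1.2-fold higher number from compound 2 to compound 3 (0.07 log units; within the scatter): adding a hydrogen-bond acceptor at this carbon leaves the number within the scatter. Replacing the whole aryl group on the amine nitrogen gives a 1.6-fold higher number from compound 1 to compound 3 (0.19 log units; within the scatter), which also stays within the scatter, so 3-chloro-4-fluorophenyl, 4-methylphenyl and 4-methoxyphenyl cannot be ordered in this assay. No evidence is available that could explain these small steps.

Still open, as far as these compounds go, is whether any group at this aromatic carbon moves the number beyond the scatter, and an amine or a carboxylic acid there would test this. Also open, from the compounds shown here alone, is whether the ethyl ester on the core matters, which an amide in its place would address.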